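Shortening the alkyl chain: what to expect for compound 3

A few compounds are considered here, and "the series" means these few. Any claim that something is new, unique, unknown or untested is made for them only; others in the source may bear on it.

Measured so far:
compound 1, `CCCCCCC#Cc1cc2cn(COCCO)c(=O)nc2o1`: > 50000 nM
compound 2, `CCCCCCCCCc1cc2cn(COCCO)c(=O)nc2o1`: >= 100000 nM

In a functional assay on HEL cells (Homo sapiens) (on this read-out lower numbers stand for higher toxicity in this test and higher numbers for lower toxicity in this test), compound 1 gives > 50000 nM, which is a limit of the test rather than a number. Compound 2 likewise gives >= 100000 nM in this assay, again a limit and not a number. So compound 2 stands at a limit (the limit of >= 100000 nM in this assay, at which 1 of the 2 values shown sits), and the one other value shown is a limit as well (the limit of > 50000 nM in this assay, at which 1 of the 2 values shown sits). Among the measured compounds shown here, no step between two measured compounds is available, so nothing shows how a change of chain length moves the read-out here.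

Compound 3, `CCCCCc1cc2cn(COCCO)c(=O)nc2o1`, has not been measured yet. It differs from compound 2 by hydrogen in place of butyl on a saturated chain carbon, five bonds along the chain from an aromatic carbon. With both measured values sitting at limits, no step beyond the usual scatter is expected in this assay. For compound 3 the estimate is 100000 nM, with a range from 30000 nM to 300000 nM, meaning an expected step of a number no higher from compound 2 to compound 3 (the limit leaves the size open).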

Compound 3, half-maximal cytotoxic concentration: > 200000 nM
Compound 3 gave a limit, no number; the forecaster's own chance of this, stated with the estimate: 85%; middle value at least 2.0-fold (0.30 log units) from the limit.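

Among the compounds shown here, compound 2 and compound 3 both give limits rather than numbers in this assay, so no step between them can be read. The compounds shown leave open whether the length of the chain changes toxicity in this test at all.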